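Swapping phenoxy for dimethylamino on a cytotoxic core

The compounds below may be only part of what the source reports. "The series", "measured", "known", "first", "only" and "open" are said of these compounds alone.

Measured so far in a functional assay on MDA-MB-468 cells (Homo sapiens) for cytotoxicity, read by sulforhodamine B assay, with a stated time of 48 h, tested at 100 nM; a lower number here means a stronger effect, a higher number a weaker effect of the compound at the concentration tested:
- compound 1 `COc1cc(C)cc(-c2c(-c3ccnc(-c4ccc(C(C)=O)cc4)c3)cnn2CC#N)c1` gives 68%
- compound 2 `COc1cc(C)cc(-c2nn(CC#N)cc2-c2ccc(-c3cccc(C(C)=O)c3)nc2)c1` gives 9%
- compound 3 `Cc1cc(O)cc(-c2nn(CC#N)cc2-c2ccnc(-c3ccc(Oc4ccccc4)cc3)c2)c1` gives 88%

Among these three numbers compound 3 stands highest, which in this assay means the weakest effect at the tested concentration. Its nearest neighbour is compound 1, whose number is lower by an amount beyond the usual scatter, and compound 2 lies far below both. None of the three pairs differs in only one place, so no single structural step can be read from them.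

Compound 4 `Cc1cc(O)cc(-c2nn(CC#N)cc2-c2ccnc(-c3ccc(N(C)C)cc3)c2)c1` differs from compound 3 in one place: dimethylamino in place of phenoxy on an aromatic carbon. The group that leaves and the group that enters are both uncharged and neither adds a hydrogen-bond donor, so the swap is a modest one on paper. The three measured compounds give no guide to how this assay answers such a change. A moderate downward step from compound 3 to compound 4 is expected, a number 10 percentage points lower from compound 3 to compound 4 (within the scatter), with wide uncertainty. The estimate for compound 4 is 78%, in a range from 45% to 100%.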

Compound 4, a percentage reported as activity, at one concentration (the size of the read-out at that concentration, not a potency): 77%
Compound 4: middle estimate off by 1 percentage points, on the high side; the range from low to high includes it.
By their numbers in this assay, from the lowest: compound 2; then compounds 1 and 4 (each within the scatter of the next); then compound 3.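

In this assay, within the data shown here, the swap of phenoxy for dimethylamino, on an aromatic carbon para to a large group, gives a number 11 percentage points lower from compound 3 to compound 4 (beyond the scatter) and is the first single change that can be read at this position. The read-out responds to this change, but only modestly, even though the group shrinks from 7 heavy atoms to 3, loses its aromatic ring and keeps the same count of hydrogen-bond acceptors. Nothing in the available data explains the shift.

The compounds shown leave open whether the response comes from removing the ring or from placing a nitrogen on the aromatic carbon. A morpholine or a methoxy group at the same position would help separate those two possibilities, and a carboxylic acid there would test a quite different kind of group.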